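The source may hold more compounds than are shown below. What is called first, only, known or untested is meant among the compounds shown, and "the series" means these compounds.

Measured so far:
compound 1 `CCn1c(=N)sc2cc(OC(F)(F)F)ccc21` — 5 mg/kg
compound 2 `N=c1sc2cc(OC(F)(F)F)ccc2n1CCS(=O)(=O)O` — > 10 mg/kg

In a functional assay on the whole organism with Rattus norvegicus as the target (a higher number here means that more compound is needed for the effect, a lower number that less compound is needed), compound 1 gives 5 mg/kg. For compound 2 this assay reports only a limit, > 10 mg/kg, so compound 2 stands at the edge of the measured range without a number of its own. Among the compounds with values here, the one measured step, an at least 2.0-fold higher number from compound 1 to compound 2 (0.30 log units; that floor lies within the scatter), has its floor inside the scatter; how far beyond that floor it goes is not known, since the limit of > 10 mg/kg in this assay, at which 1 of the 2 values shown sits, is all that marks it.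

Compound 3 `C[S+]([O-])CCn1c(=N)sc2cc(OC(F)(F)F)ccc21` is not yet measured. It differs from compound 2 by a group of 3 heavy atoms (1 carbon, 1 oxygen, 1 sulfur; no ring) in place of a group of 4 heavy atoms (3 oxygen, 1 sulfur; no ring), on a saturated chain carbon, two bonds along the chain from an aromatic nitrogen. Within the data shown here, the only step that bears on this is the sulfo step, now run backwards: the group whose arrival gave the rise leaves again, while the entering group has no measured counterpart. Compound 3 is therefore expected to sit between the two measured values, at 7 mg/kg, with a range from 3 mg/kg to 20 mg/kg. The expected step is an at least 1.4-fold lower number from compound 2 to compound 3 (0.15 log units; that floor lies within the scatter), and a second limit cannot be ruled out.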

Compound 3, dose for half-maximal effect: 1.1 mg/kg
For compound 3 the middle estimate is 6.4-fold (0.80 log units) above the measured one; measured number outside the range, below it.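

At the saturated chain carbon, two bonds along the chain from an aromatic nitrogen, a substituent can lower the number in this assay and not only leave it unchanged or raise it: replacing hydrogen with the group of compound 3 gives a 4.5-fold lower number from compound 1 to compound 3 (0.66 log units; beyond the scatter) and lies beyond the scatter. The earlier sulfo step had shown no change beyond the scatter at its floor, whereas exchanging the sulfo group for this group gives an at least 9.0-fold lower number from compound 2 to compound 3 (0.95 log units; beyond the scatter) at this same place. As far as these compounds go, the full size of that exchange stays unknown, since compound 2 carries only a limit of the assay: the limit of > 10 mg/kg in this assay, at which 1 of the 3 values shown sits.

Open, from the compounds shown here alone, is whether a carboxylic acid, an amine or a longer chain at this carbon would follow compound 3 or compound 2. Also open, going by these compounds, is how a methylthio or methylsulfonyl group would compare with the group of compound 3 in the same place.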